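The source may hold more compounds than are shown below. What is called first, only, known or untested is meant among the compounds shown, and "the series" means these compounds.

Working notes on the series. The shared core of compound 1 `CCCCOc1no[n+]([O-])c1S(=O)(=O)c1ccccc1` carries a butoxy group; in a functional assay on MDA-MB-231 cells (Homo sapiens) for cytotoxicity, read by MTT assay, with a stated time of 48 h (on this read-out higher numbers stand for weaker inhibition and lower numbers for stronger inhibition), compound 1 gives 9870 nM, the higher of the two numbers read here. Compound 2 `CC(C)=CCC/C(C)=C/CC/C(C)=C/CSc1ccccc1C(=O)NCC(=O)OC(C)CCOc1no[n+]([O-])c1S(=O)(=O)c1ccccc1` extends the same core through a long chain, and in this assay compound 2 gives 7260 nM, which sits within the scatter of compound 1, so the two are not told apart. Compound 3 `CC(C)=CCC/C(C)=C/CC/C(C)=C/CSc1ccccc1C(=O)N[C@@H](C)C(=O)OCCCCOc1no[n+]([O-])c1S(=O)(=O)c1ccccc1` carries a related extension; for compound 3 this assay reports only a limit, > 50000 nM, and no number (the limit of > 50000 nM in this assay, at which 1 of the 3 values shown sits).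

Compound 4 `CCC(C)Oc1no[n+]([O-])c1S(=O)(=O)c1ccccc1` is not yet measured. It differs from compound 1 by sec-butyl in place of butyl on an oxygen on an aromatic ring. Among the compounds with values here, no measured step shows how this assay answers a branched against a straight chain on the oxygen on the aromatic ring, so no direction is argued, and the step from compound 1 to compound 4 is expected to stay within the scatter: a 1.0-fold lower number from compound 1 to compound 4 (0.02 log units; within the scatter). Compound 4 is therefore expected at 9500 nM, with a range from 4000 nM to 25000 nM.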

Compound 4, half-maximal inhibitory concentration: 15300 nM
Beside the measured number, compound 4's estimate is 1.6-fold (0.21 log units) below it; the measured number falls inside the stated range.
By their numbers in this assay, from the lowest: compounds 2, 1 and 4 (each within the scatter of the next, the first and the last beyond it). At a limit, above all of these: compound 3.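

Within the data shown here, this is the first step that reads the position on an oxygen on an aromatic ring: in this assay, sec-butyl in place of butyl gives a 1.6-fold higher number from compound 1 to compound 4 (0.19 log units; within the scatter), so this assay does not tell the branched chain from the straight one. The answer holds for this one pair only, and it shows that this change of chain shape, with the same atoms, leaves the number inside the usual scatter. Nothing measured in the series gives a cause for this step.

Still open, going by these compounds, is how this assay answers a shorter chain such as methyl, a longer chain such as octyl, or a cyclic group such as cyclohexyl on this oxygen. A chain ending in an amine or a carboxylic acid at this position is equally unresolved.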